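This account rests on a few compounds, and the source may have more. Where it says the series, first, only, none or still open, it means among the compounds named here.

Three compounds built on one shared core were tested in a functional assay on cells (Panel breast (Carcinoma cell lines), Homo sapiens) for antiproliferative activity; on this read-out higher numbers stand for weaker inhibition of growth and lower numbers for stronger inhibition of growth. Compound 1 `COc1cccc(-c2nn(-c3ccccc3)cc2-c2ccnc(NCCNC(=O)Nc3cccc(C(F)(F)F)c3)c2)c1` gives 2230 nM. Compound 2 `COc1cccc(-c2nn(-c3ccccc3)cc2-c2ccnc(NCCCNC(=O)Nc3ccc(Cl)c(Cl)c3)c2)c1` gives 2690 nM. Compound 3 `O=C(NCCCNc1cc(-c2cn(-c3ccccc3)nc2-c2cccc(O)c2)ccn1)c1ccccc1` gives 2130 nM, the lowest of the three numbers, yet its gaps to compound 1 and to compound 2 both lie within the usual scatter, so the three cannot be told apart on these data. Compound 4 `O=C(NCCCNc1cc(-c2cn(-c3ccccc3)nc2-c2cccc(O)c2)ccn1)c1ccc(F)cc1` differs from compound 3 only by fluoro in place of hydrogen on an aromatic carbon. Within the data shown here, no measured pair shows what this change does here, so no step beyond the scatter is expected in either direction. The value for compound 4 in this assay is estimated at 2000 nM, within a range from 1000 nM to 4500 nM. The step that this estimate means, a 1.1-fold lower number from compound 3 to compound 4 (0.03 log units; within the scatter), is expected to stay small.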

Compound 4, concentration for 50% growth inhibition: 1890 nM
Beside the measured number, compound 4's estimate is 1.1-fold (0.02 log units) above it; low and high end bracket the measured number.
By their numbers in this assay, from the lowest: compounds 4, 3, 1 and 2 (each within the scatter of the next).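

Among these compounds, compound 3 and compound 4 form the first pair that isolates a single change in this assay. Going from phenyl to 4-fluorophenyl gives a 1.1-fold lower number from compound 3 to compound 4 (0.05 log units; within the scatter) and shows that this position can carry a fluoro without a step beyond the scatter. Nothing shown offers an explanation for this result. The compounds shown leave open how a larger or differently charged group at this position, such as an amine or a carboxylic acid, would read, and whether fluoro elsewhere on this ring would read the same.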